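Alkoxy variation on the shared core

The compounds below may be only part of what the source reports. "The series", "measured", "known", "first", "only" and "open" are said of these compounds alone.

Compound 3 `CC(C)Oc1nc(C(C)(C)C)ccc1CNC(=O)C(C)c1ccc(NS(C)(=O)=O)c(F)c1` gives 2.3 nM in an assay on cells for antagonist activity at transient receptor potential cation channel subfamily V member 1 (Homo sapiens), read by FLIPR and calcium flux, with a stated time of 6 min; on this read-out lower numbers stand for stronger inhibition and higher numbers for weaker inhibition. Among the three numbers so far it stands second highest. Its nearest neighbour is compound 2 `CCCCCCOc1nc(C(C)(C)C)ccc1CNC(=O)C(C)c1ccc(NS(C)(=O)=O)c(F)c1` at 2.7 nM, and the step of a 1.2-fold lower number from compound 2 to compound 3 (0.07 log units; within the scatter) lies within the scatter. Its furthest is compound 1 `CCCCN(C)c1nc(C(C)(C)C)ccc1CNC(=O)C(C)c1ccc(NS(C)(=O)=O)c(F)c1` at 1.2 nM, and a 1.9-fold higher number from compound 1 to compound 3 (0.28 log units; within the scatter) also stays within the scatter. Compound 4 `CC(C)COc1nc(C(C)(C)C)ccc1CNC(=O)C(C)c1ccc(NS(C)(=O)=O)c(F)c1` carries isobutyl in place of isopropyl on an oxygen on an aromatic ring. Among the compounds with values here, the step that bears on this change is a 1.2-fold lower number from compound 2 to compound 3 (0.07 log units; within the scatter), where two chains of different length on the same oxygen gave numbers within the scatter of each other; the only step beyond the scatter, a 2.3-fold higher number from compound 1 to compound 2 (0.35 log units; beyond the scatter), concerns a different group. No shift beyond the scatter is therefore expected in this assay, the expected step being a 1.1-fold higher number from compound 3 to compound 4 (0.04 log units; within the scatter). Compound 4 is estimated at 2.5 nM, range 1.2 nM to 5.5 nM.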

Compound 4, inhibition constant: 0.6 nM
Estimate against measurement, compound 4: 4.2-fold (0.62 log units) above, and the stated range ends above it.
By their numbers in this assay, from the lowest: compounds 4, 1, 3 and 2 (each within the scatter of the next, the first and the last beyond it).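

On an oxygen on an aromatic ring, the chain can move the number in this assay beyond the scatter: isobutyl does so against isopropyl (a 3.8-fold lower number from compound 3 to compound 4 (0.58 log units; beyond the scatter)) and against hexyl (a 4.5-fold lower number from compound 2 to compound 4 (0.65 log units; beyond the scatter)), whereas hexyl and isopropyl alone had stayed within it. The isobutoxy group and the butyl(methyl)amino group remain within the scatter of each other (a 2.0-fold lower number from compound 1 to compound 4 (0.30 log units; within the scatter)). Nothing measured here accounts for the isobutyl step. Open, on these data alone, is whether the response to the chain is specific to isobutyl, or extends to neopentyl or cyclopropylmethyl on the same oxygen.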